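The source may report more compounds than this note shows. Statements on the series, on what has been measured and on what is new or still open speak of the compounds shown alone.

In an ADME assay on MRC5 cells (Homo sapiens) for cytotoxicity, read by fluorescence and resazurin assay, with a stated time of 3 days (on this read-out lower numbers stand for higher toxicity in this test and higher numbers for lower toxicity in this test), compound 1 `N#Cc1ccc(C2CCN(C(=O)Nc3cc(-c4ccccn4)n[nH]3)CC2)cc1` gives > 64000 nM, a limit and not a number. Compound 2 `O=C(Nc1cc(-c2ccccn2)n[nH]1)N1CCC(c2ccc(F)cc2)CC1` gives > 64000 nM, also a limit. Compound 3 `O=C(Nc1cc(-c2ccccn2)n[nH]1)N1CCC(c2ccccc2)CC1` gives > 64000 nM, again a limit. The three compounds thus all sit at the limit of > 64000 nM in this assay, at which 3 of the 3 values shown sit, and compound 1 is known only by that limit.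

The change to compound 4 `O=C(Nc1cc(-c2ccccn2)n[nH]1)N1CCC(Oc2ccccn2)CC1` is (pyridin-2-yl)oxy in place of 4-cyanophenyl on a saturated ring carbon. The measured steps that bear on it are a step that the two limits leave unreadable from compound 1 to compound 2, a step that the two limits leave unreadable from compound 1 to compound 3 and a step that the two limits leave unreadable from compound 2 to compound 3. None has a readable size, and none replaces the whole 4-cyanophenyl group, so they bear on it only loosely.

For compound 1 the limit of > 64000 nM remains the only anchor for the expectation. In this assay no step beyond the scatter is expected, and the expected step is a number no higher from compound 1 to compound 4 (the limit leaves the size open). The estimate for compound 4 is 64000 nM, with an expected range of 30000 nM to 64000 nM.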

Compound 4, half-maximal cytotoxic concentration: > 63000 nM
Compound 4: a limit, no number (the forecaster's own chance of this, stated with the estimate: 85%); the middle value does not contradict the limit.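

In this assay, going by these compounds alone, compound 1, compound 2, compound 3 and compound 4 are all known only as limits, so no step to compound 4 can be read. The compounds shown leave open where any true half-maximal cytotoxic concentration lies, and whether any of these changes shifts it.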